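Thiophene Replacing Chlorophenyl on the Sulfonylurea Antagonist

The source may hold more compounds than are shown below. What is called first, only, known or untested is meant among the compounds shown, and "the series" means these compounds.

The measured compounds:
Compound 1, `Cc1nc(C)c(S(=O)(=O)NC(=O)NC/C=C2\CCCc3cnn(Cc4ccc(Cl)cc4Cl)c32)s1`, 4 nM
Compound 2, `COc1ccccc1S(=O)(=O)NC(=O)NC/C=C1\CCCc2cnn(Cc3ccc(Cl)cc3Cl)c21`, 114 nM
Compound 3, `O=C(NC/C=C1\CCCc2cnn(Cc3ccc(Cl)cc3Cl)c21)NS(=O)(=O)c1ccc(Cl)cc1`, 12 nM

All three share one core and differ only in the group on the sulfonyl sulfur. In a functional assay on CHO-K1 cells for antagonist activity at prostaglandin E2 receptor EP3 subtype (Homo sapiens), read by TR-FRET and cAMP accumulation, with a stated time of 30 min (on this read-out higher numbers stand for weaker inhibition and lower numbers for stronger inhibition), compound 3 gives 12 nM, the second highest of the three numbers. Its nearest neighbour is compound 1, since a 3.0-fold higher number from compound 1 to compound 3 (0.48 log units; beyond the scatter); its furthest is compound 2, since a 9.5-fold lower number from compound 2 to compound 3 (0.98 log units; beyond the scatter). The widest gap among the measured compounds is a 29-fold higher number from compound 1 to compound 2 (1.45 log units; beyond the scatter).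

Compound 4, `O=C(NC/C=C1\CCCc2cnn(Cc3ccc(Cl)cc3Cl)c21)NS(=O)(=O)c1cccs1`, carries the change (thiophen-2-yl in place of 4-chlorophenyl on a sulfonyl sulfur). The step that bears most directly on it is a 3.0-fold higher number from compound 1 to compound 3 (0.48 log units; beyond the scatter), where a five-membered aromatic ring with hetero atoms, measured in compound 1, gave a lower number than the six-membered carbon ring of compound 3. The entering thiophen-2-yl is also a five-membered ring with one hetero atom, though it lacks the two methyl groups of compound 1. The step of a 9.5-fold lower number from compound 2 to compound 3 (0.98 log units; beyond the scatter) shows that a substituted six-membered ring can also raise the number markedly, so the range of outcomes on this position is wide.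

Compound 4 is therefore expected to land near compound 3 or somewhat lower, an estimated 1.5-fold lower number from compound 3 to compound 4 (0.18 log units; within the scatter), giving an expected 8 nM with a range of 2.5 nM to 25 nM.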

Compound 4, half-maximal inhibitory concentration: 28 nM
Estimate against measurement, compound 4: 3.5-fold (0.54 log units) below; the measured number lies above the stated range.
By their numbers in this assay, from the lowest: compound 1; then compound 3; then compound 4; then compound 2.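

Compound 4 shows that a five-membered aromatic ring with a hetero atom on the sulfonyl sulfur does not by itself give a low number in this assay: thiophen-2-yl falls well short of the 2,4-dimethyl-1,3-thiazol-5-yl of the best compound here (a 7.0-fold higher number from compound 1 to compound 4 (0.85 log units; beyond the scatter)). Ring size does not sort these four compounds either, since thiophen-2-yl gives up ground against 4-chlorophenyl (a 2.3-fold higher number from compound 3 to compound 4 (0.37 log units; beyond the scatter)) yet improves on 2-methoxyphenyl (a 4.1-fold lower number from compound 2 to compound 4 (0.61 log units; beyond the scatter)), so compound 3 goes against any rule favouring the five-membered ring and compound 2 fits one. Nothing shown offers a reason for this order.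

Compound 1 and compound 4 differ in both the second ring hetero atom and the two methyl groups, so the compounds shown cannot say which of these accounts for the gap; an unsubstituted 1,3-thiazol-5-yl or a dimethylthiophene would separate them. Also open, from the compounds shown here alone, is what the chlorine of compound 3 contributes, which plain phenyl on the same sulfonyl sulfur would address, and how an amine or a carboxylic acid on the ring would read.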